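The compounds below may be only part of what the source reports. "The series", "measured", "known", "first", "only" and "open" are said of these compounds alone.

Compound 1, with the structure `CC1CCN(c2nc(-c3ccccc3)nc3ccc(I)cc23)CC1`, has the lower of the two measured numbers in a functional assay on the whole organism for inhibition, with Rattus norvegicus as the target, read by paw edema, with stated times of 4 days, 1 h and 2 h, at a dose of 100 mg/kg by the oral route (a higher number here means more inhibition at the dose given (going by the name of the read-out), a lower number less inhibition), where compound 1 gives 56.4%. The other measured compound, compound 2, with the structure `Ic1ccc2nc(-c3ccccc3)nc(N3CCC(c4ccccc4)CC3)c2c1`, gives 82.5% in this assay. Going by the values given here, the one step measured so far runs a number 26.1 percentage points higher from compound 1 to compound 2 (beyond the scatter), and it arises from a phenyl in place of methyl on a saturated ring carbon, a part of the molecule that is not touched in the step considered here.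

The unmeasured compound 3 has the structure `CC1CCN(c2nc(-c3ccc(Cl)cc3)nc3ccc(I)cc23)CC1`. It differs from compound 1 by chloro in place of hydrogen on an aromatic carbon. Among the compounds with values here, no measured step concerns this part of the molecule, so the only available step, the one from compound 1 to compound 2, gives no direct guide; it shows only that a change elsewhere moved the read-out modestly. In the absence of a relevant measured step, the change in compound 3 is expected to produce a number 1.6 percentage points higher from compound 1 to compound 3 (within the scatter), a step not clearly beyond the scatter. Compound 3 is therefore estimated to give 58% in this assay, within a range from 40% to 76%.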

Compound 3, a percentage reported as inhibition, in the whole organism at one dose (the size of the read-out at that dose, not a potency): 45.8%
Estimate against measurement, compound 3: 12.2 percentage points above; the range from low to high includes it.
By their numbers in this assay, from the lowest: compound 3; then compound 1; then compound 2.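

Going by these compounds alone, the change from phenyl to 4-chlorophenyl gives the first reading on this part of the molecule, which the step between the earlier compounds left untouched: in this assay the result is a number 10.6 percentage points lower from compound 1 to compound 3 (beyond the scatter). Within the data shown here, this position, an aromatic carbon para to a large group, is therefore not indifferent to chloro in place of hydrogen, and the number moves the opposite way from the one earlier step, a number 26.1 percentage points higher from compound 1 to compound 2 (beyond the scatter), which is the larger of the two. Nothing at hand bears on why the chloro group lowers the number.

The compounds shown leave open whether this step depends on the methyl group on the saturated ring carbon, since chloro on the same aromatic carbon appears only with that methyl group and not with the phenyl group of compound 2. They also leave open whether the drop belongs to chloro itself or would recur with another group at this place, such as fluoro, methoxy or an amine, and whether it would hold at a dose other than the single one tested.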